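The compounds below may be only part of what the source reports. "The series", "measured", "known", "first", "only" and "open" are said of these compounds alone.

Compound 1 `Oc1ccc(-c2cc3ccccc3o2)c2cccnc12` gives 4.3 10^-6 cm/s in an ADME assay for permeability, using PAMPA, with a stated time of 10 h, tested at 100 ug/mL; a lower number here means that the compound crosses the layer more slowly, a higher number that the compound crosses the layer faster. Compound 2 `Oc1ccc2cc(-c3ccc(O)c4ncccc34)oc2c1` gives 15.8 10^-6 cm/s and compound 3 `Oc1ccc2oc(-c3ccc(O)c4ncccc34)cc2c1` gives 15.5 10^-6 cm/s, two values within the scatter of each other. Hydroxy in place of hydrogen on an aromatic carbon gives a 3.7-fold higher number from compound 1 to compound 2 (0.57 log units; beyond the scatter) and a 3.6-fold higher number from compound 1 to compound 3 (0.56 log units; beyond the scatter). Compound 3 therefore stands level with compound 2 and clear of compound 1. Compound 4 `Cc1c(-c2ccc(O)c3ncccc23)oc2ccc(O)cc12` differs from compound 3 by one change: methyl in place of hydrogen on an aromatic carbon. Among the measured compounds shown here, no measured step places a methyl, so the two modest hydroxy steps bear on it only loosely. On these data alone, no step beyond the scatter is expected in this assay, and the direction stays open. The expected step is a 1.0-fold higher number from compound 3 to compound 4 (0.01 log units; within the scatter). Compound 4 is estimated at 16 10^-6 cm/s, with an expected range of 8 10^-6 cm/s to 30 10^-6 cm/s.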

Compound 4, apparent permeability: 16.8 10^-6 cm/s
Estimate against measurement, compound 4: 1.1-fold (0.02 log units) below; the measured number falls inside the stated range.
By their numbers in this assay, from the lowest: compound 1; then compounds 3, 2 and 4 (each within the scatter of the next).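

In this assay methyl in place of hydrogen on an aromatic carbon of the five-membered aromatic ring gives a 1.1-fold higher number from compound 3 to compound 4 (0.03 log units; within the scatter) and so no readable shift at this place. Among the compounds shown here, the earlier steps placed only hydroxy, so this is the one reading for a methyl, next to the ring atom that bears a large group. Nothing at hand gives a cause for this result.

On these data alone, whether a longer chain, an amine or a carboxylic acid at this position would also leave the number level stays open. So does whether methyl would read the same on the core of compound 2.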